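The compounds below may be only part of what the source reports. "The series", "measured", "known", "first", "only" and "open" are said of these compounds alone.

Measured so far:
- Compound 1, `COc1ccc(-c2cc(=O)c3c(OC)c(OC)c(OC)c(OC)c3o2)c(OC)c1`: 15 ug/mL
- Compound 2, `COc1c(OC)c(OC)c2c(=O)cc(-c3ccc(OC(C)=O)cc3)oc2c1OC`: 3 ug/mL
- Compound 3, `COc1ccc(OC)c(-c2cc(=O)c3c(OC)c(OC)c(OC)c(OC)c3o2)c1`: 4 ug/mL

All three were tested in a functional assay on KB cells (Homo sapiens) for cytotoxicity; on this read-out lower numbers stand for an effect already at smaller amounts and higher numbers for an effect only at larger amounts of compound. Compound 3 gives 4 ug/mL, the second highest of the three numbers. Its nearest neighbour is compound 2, whose value lies within the usual scatter, so no order between these two can be read. Compound 1 stands furthest from compound 3, with a higher number that lies beyond the scatter.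

Compound 4, `COc1cc(OC)c(-c2cc(=O)c3c(OC)c(OC)c(OC)c(OC)c3o2)cc1OC`, has not yet been measured. It differs from compound 3 in one place: methoxy in place of hydrogen on an aromatic carbon. The new methoxy sits on an aromatic carbon of a six-membered aromatic ring of carbon only, ortho to a methoxy group, meta to a methoxy group and para to a large group.

Among the measured compounds shown here, no measured pair shows this exact change, so the expectation rests on the spread of the three numbers alone. In this assay a modest step is expected from compound 3 to compound 4, a 1.5-fold higher number from compound 3 to compound 4 (0.18 log units; within the scatter), toward a somewhat higher number, though not clearly beyond the scatter. Compound 4 is therefore estimated at 6 ug/mL, with a range from 2 ug/mL to 20 ug/mL.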

Compound 4, concentration for half-maximal effect: 13 ug/mL
Compound 4: middle estimate off by 2.2-fold (0.34 log units), on the low side, within the range that was stated.
By their numbers in this assay, from the lowest: compounds 2 and 3 (each within the scatter of the next); then compounds 4 and 1 (each within the scatter of the next).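

In this assay, methoxy in place of hydrogen on this aromatic carbon (ortho to a methoxy group, meta to a methoxy group and para to a large group) gives a 3.3-fold higher number from compound 3 to compound 4 (0.51 log units; beyond the scatter), so this position does respond to the change, and the effect then appears only at larger amounts of compound. The same kind of exchange starting from compound 1 gives a 1.2-fold lower number from compound 1 to compound 4 (0.06 log units; within the scatter), which stays within the usual scatter, so adding a methoxy to this ring does not shift the number equally in both pairs. Nothing available here explains that contrast.

Beyond hydrogen and methoxy, no other group at this carbon is shown. From the compounds shown here alone, it remains open whether a hydroxy group, a chlorine atom or an amine there would keep the higher number of compound 4 or come closer to compound 3.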